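Trifluoromethyl for Heptyl on an Amide Carbonyl Carbon

This account rests on a few compounds, and the source may have more. Where it says the series, first, only, none or still open, it means among the compounds named here.

Compound 1 `CCCCCCCCCCCCCCCC(=O)OCCSC[C@H](N)C(=O)N[C@@H](CO)C(=O)OC`: 3.63 nM
Compound 2 `CCCCCCCCCCCCCCCC(=O)OCCSC[C@H](NC(=O)CCCCCCC)C(=O)N[C@@H](CO)C(=O)OC`: 3.8 nM

Of the compounds shown here, two have been measured in a functional assay on HEK293 cells for agonist activity at Toll-like receptor 2 (Homo sapiens), read by reporter gene assay, with a stated time of 12 h; a lower number here means that less compound is needed, a higher number that more compound is needed for the effect. Compound 1 carries a free amine; compound 2 carries a heptylcarbonyl on that nitrogen, and the step of a 1.0-fold higher number from compound 1 to compound 2 (0.02 log units; within the scatter) shows that this addition left the number essentially unchanged. Compound 2 thus stands with the higher of the two numbers, but its gap to compound 1 lies within the scatter, so no order between the two can be claimed.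

Compound 3 `CCCCCCCCCCCCCCCC(=O)OCCSC[C@H](NC(=O)C(F)(F)F)C(=O)N[C@@H](CO)C(=O)OC` differs from compound 2 by trifluoromethyl in place of heptyl on a carbonyl carbon. Going by the values given here, only one measured step touches this nitrogen, the step from compound 1 to compound 2, and it was flat: a long chain on the amide changed nothing beyond the scatter. Among the compounds with values here, no measured pair tests a trifluoromethyl here, so the expectation rests on the shared scaffold having carried both hydrogen and heptylcarbonyl without loss. On that basis compound 3 is expected to stay close to compound 2, with a step of about a 1.3-fold higher number from compound 2 to compound 3 (0.12 log units; within the scatter). The estimate for compound 3 in this assay is 5 nM, with a range from 1.5 nM to 20 nM.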

Compound 3, half-maximal effective concentration: 4.5 nM
Estimate against measurement, compound 3: 1.1-fold (0.05 log units) above; the range from low to high includes it.
By their numbers in this assay, from the lowest: compounds 1, 2 and 3 (each within the scatter of the next).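

In this assay, replacing heptyl with trifluoromethyl on the carbonyl carbon gives a 1.2-fold higher number from compound 2 to compound 3 (0.07 log units; within the scatter), and putting (trifluoromethyl)carbonyl in place of hydrogen on the amine nitrogen gives a 1.2-fold higher number from compound 1 to compound 3 (0.09 log units; within the scatter). Going by these compounds alone, until now, heptylcarbonyl was the only group tested against the free amine, so the flat result rested on a single acyl group; a second acyl group, carrying fluorine instead of a carbon chain, now gives the same reading, and hydrogen, heptylcarbonyl and (trifluoromethyl)carbonyl on this nitrogen cannot be put in any order. Nothing in the available data gives a reason for this flatness.

Going by these compounds, it remains open whether the tolerance at this nitrogen extends to a group of another kind, such as a benzoyl ring, a carboxylic acid at the end of a succinyl chain, or a basic amine on the acyl chain. All three compounds also share the long ester chain and the serine methyl ester, so they say nothing about how much those parts contribute to the effect.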